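The source may hold more compounds than are shown below. What is called first, only, known or untested is meant among the compounds shown, and "the series" means these compounds.

Working notes on the series, read in an ADME assay on the whole organism (Rattus norvegicus, strain Sprague-Dawley) for pharmacokinetics, read by LC-MS, with a stated time of 30 min, at a dose of 1 mg/kg by the intravenous route; on this read-out higher numbers stand for fast clearance and lower numbers for slow clearance. Compound 1 `N#Cc1ccc(O[C@H]2CN(S(=O)(=O)c3ccc(C(F)(F)F)cc3)C[C@@]2(O)CO)cc1F` gives 50 mL/min/kg. Compound 2 `N#Cc1ccc(O[C@H]2CN(S(=O)(=O)c3ccc(Cl)cc3Cl)C[C@@]2(O)CN)cc1F` gives 40 mL/min/kg, and compound 3 `N#Cc1ccc(O[C@H]2CN(S(=O)(=O)c3ccc(Cl)cc3Cl)C[C@]2(O)CO)cc1F` gives 54 mL/min/kg. The three values all lie within the scatter of one another, so compound 1 stands in the middle of a tight group and is not separated from either neighbour.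

The next compound for this assay is compound 4 `N#Cc1ccc(O[C@H]2CN(S(=O)(=O)c3ccccc3C#N)C[C@@]2(O)CO)cc1F`. It carries 2-cyanophenyl in place of 4-(trifluoromethyl)phenyl on a sulfonyl sulfur. Among the measured compounds shown here, no measured pair differs in one place only, so no direct precedent exists for this change. The expectation rests on the narrow spread alone, with compound 1 at 50 mL/min/kg as the starting point, and no step beyond the scatter is expected, in either direction. The expected step is a 1.1-fold lower number from compound 1 to compound 4 (0.05 log units; within the scatter). For compound 4 the estimated clearance is 45 mL/min/kg, with an expected range of 25 mL/min/kg to 75 mL/min/kg.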

Compound 4, clearance: 39 mL/min/kg
Compound 4: middle estimate off by 1.2-fold (0.06 log units), on the high side, within the range that was stated.
By their numbers in this assay, from the lowest: compounds 4, 2, 1 and 3 (each within the scatter of the next).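

In this assay the series now has its first comparison in one place only: 2-cyanophenyl in place of 4-(trifluoromethyl)phenyl on a sulfonyl sulfur gives a 1.3-fold lower number from compound 1 to compound 4 (0.11 log units; within the scatter), a step within the scatter. At this position, therefore, clearance does not separate the two groups, although the entering group has fewer heavy atoms and adds a hydrogen-bond acceptor. No measured property on hand bears on the reason for this result.

Going by these compounds, it remains open whether a phenyl group carrying an amine or a carboxylic acid, or a longer alkyl chain on the sulfonyl sulfur, would give a step beyond the scatter. On these data alone, it also remains open whether the same change gives a similar step when the rest of the core differs from that of compound 1.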